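The compounds below may be only part of what the source reports. "The series", "measured", "known", "first", "only" and "open" are said of these compounds alone.

In an ADME assay on MT4 cells (Homo sapiens) for cytotoxicity, read by MTT assay, with a stated time of 5 days (on this read-out lower numbers stand for higher toxicity in this test and higher numbers for lower toxicity in this test), three related compounds have been read so far. Compound 1 (`COc1cc(Oc2c(C)cc(C#N)cc2C)cc(Nc2ccc(C#N)cc2)n1`) gives > 147000 nM as a limit of the assay and not a number. Compound 3 (`Cc1cc(C)c(Oc2cc(Nc3ccc(C#N)cc3)[nH]c(=O)c2Br)c(C)c1`) gives > 294000 nM as a limit too. For the measured compounds named here, compound 2 (`Cc1cc(C#N)cc(C)c1Oc1cc(Nc2ccc(C#N)cc2)[nH]c(=O)c1`) gives 25000 nM as the only true number of the three. Compound 1 therefore stands with a limit alone, so any step away from it is uncertain from the start.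

Compound 4 (`COc1cc(Oc2c(C)cccc2C)cc(Nc2ccc(C#N)cc2)n1`) keeps the core of compound 1 and alters one place: hydrogen in place of cyano on an aromatic carbon with hydrogen in place of cyano on an aromatic carbon, para to a large group. Going by the values given here, no measured pair shows what this change does. Among the compounds with values here, compound 2 at 25000 nM shows only that a number can be reached with a close relative. A modest step to a lower number, meaning somewhat higher toxicity, is expected, and the estimated change is an at least 2.1-fold lower number from compound 1 to compound 4 (0.32 log units; beyond the scatter) in this reading. For compound 4 the estimated value is 70000 nM with an expected range from 15000 nM to 250000 nM in this assay once it is measured.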

Compound 4, half-maximal cytotoxic concentration: 8500 nM
For compound 4 the middle estimate is 8.2-fold (0.92 log units) above the measured one; measured number outside the range, below it.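

In this assay, putting hydrogen in place of cyano at this place, para to a large group, gives an at least 17-fold lower number from compound 1 to compound 4 (1.23 log units; beyond the scatter), so within this pair the cyano group goes with markedly lower toxicity in this test. With hydrogen at this place, compound 4 gives 8500 nM, a true number on the core of compound 1. That step is a minimum and the true gap may be wider, because one end of it is a limit of the assay and not a number: the limit of > 147000 nM in this assay, at which 1 of the 4 values shown sits.

One pair cannot show how another group at this place, such as an amine or a carboxylic acid, would read in this assay. It also leaves open whether the same change would have a similar effect on the core of compound 2, which also carries the cyano group.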